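Adding a methoxy group to compound 2

The source may hold more compounds than are shown below. What is called first, only, known or untested is meant among the compounds shown, and "the series" means these compounds.

In an ADME assay for permeability, using PAMPA, at pH 7.4 (a lower number here means that the compound crosses the layer more slowly, a higher number that the compound crosses the layer faster), compound 1 `CN1CCc2cccc(c2)[C@@H](Nc2ccc3c(N)ncc(F)c3c2)C(=O)N(C)Cc2cc(ccc2S(=O)(=O)C2CC2)NC1=O` gives 220 nm/s and compound 2 `CN1Cc2cc(ccc2S(=O)(=O)C2CC2)NC(=O)CCc2cccc(c2)[C@@H](Nc2ccc3c(N)ncc(F)c3c2)C1=O` gives 120 nm/s, two numbers within the usual scatter of each other. The next structure, compound 3 `COc1cc2cc(c1)[C@@H](Nc1ccc3c(N)ncc(F)c3c1)C(=O)N(C)Cc1cc(ccc1S(=O)(=O)C1CC1)NC(=O)CC2`, differs from compound 2 in one place: methoxy in place of hydrogen on an aromatic carbon. For the measured compounds named here, no measured pair shows what this change does, so the expectation in this assay is no step beyond the scatter, in either direction. The estimated 1.0-fold lower number from compound 2 to compound 3 (0.02 log units; within the scatter) is therefore small. The expected value for compound 3 is 115 nm/s, with a range from 50 nm/s to 260 nm/s.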

Compound 3, apparent permeability: 290 nm/s
The estimate for compound 3 lay 2.5-fold (0.40 log units) below the measured number, outside the stated range (above it).
By their numbers in this assay, from the lowest: compounds 2, 1 and 3 (each within the scatter of the next, the first and the last beyond it).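

In this assay, for the compounds shown here, methoxy in place of hydrogen on an aromatic carbon gives a 2.4-fold higher number from compound 2 to compound 3 (0.38 log units; beyond the scatter) and so provides the first readable single change. The step is modest, but it shows that the number can respond to a change at this position, meta to two fused rings. Nothing measured here explains the step.

One pair cannot show whether this step is specific to methoxy. Going by these compounds alone, a hydroxyl group, a fluorine atom or an amine at the same carbon could give a similar step, no step or one in the opposite direction.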